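This account rests on a few compounds, and the source may have more. Where it says the series, first, only, none or still open, it means among the compounds named here.

Three compounds have been measured so far:

Compound 1, `O=[N+]([O-])c1ccc(COc2ccc(Nc3ncnc4cc5c(cc34)OCCOCCO5)cc2)cc1`, gives 55200 nM in a functional assay on SH-SY5Y cells (Homo sapiens) for antiproliferative activity, read by MTT assay, with a stated time of 72 h; a lower number here means a stronger inhibitor, a higher number a weaker inhibitor.
Compound 2, `FC(F)(F)c1ccc(COc2cccc(Nc3ncnc4cc5c(cc34)OCCOCCO5)c2)cc1`, gives 19300 nM in this assay.
Compound 3, `FC(F)(F)c1ccc(COc2cccc(Nc3ncnc4cc5c(cc34)OCCOCCOCCO5)c2)cc1`, gives 20000 nM in this assay.

All three share the same core, a two-ring heteroaromatic system fused to a large oxygen-containing ring, carrying an aryl amine with a benzyloxy-type substituent. Compound 2 has the lowest number of the three. Its neighbour, compound 3, which differs only in the size of the large ring, sits so close that the two cannot be told apart within the usual scatter. Compound 1, with a nitro group in place of trifluoromethyl and a different attachment point on the amine-bearing ring, lies beyond the scatter with the higher number.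

The next compound, compound 4, `c1ccc(COc2cccc(Nc3ncnc4cc5c(cc34)OCCOCCO5)c2)cc1`, is compound 2 with one change: hydrogen in place of trifluoromethyl on an aromatic carbon. For the measured compounds named here, no measured pair in this set shows what removing such a group does here, so the expected step from compound 2 to compound 4 in this assay cannot be anchored on data. The expectation is a small step, most likely a slightly higher number, and quite possibly none beyond the scatter.

Compound 4 is therefore expected to give about 27000 nM in this assay, within a range from 11000 nM to 65000 nM. This estimate means a step of a 1.4-fold higher number from compound 2 to compound 4 (0.15 log units; within the scatter).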

Compound 4, half-maximal inhibitory concentration: 68400 nM
The estimate for compound 4 lay 2.5-fold (0.40 log units) below the measured number; measured number outside the range, above it.
By their numbers in this assay, from the lowest: compounds 2 and 3 (each within the scatter of the next); then compounds 1 and 4 (each within the scatter of the next).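

In this assay the change from 4-(trifluoromethyl)benzyl to benzyl gives a 3.5-fold higher number from compound 2 to compound 4 (0.55 log units; beyond the scatter) and so shows that this place, on an aromatic carbon para to a large group, is not indifferent to what it carries. The earlier compounds shown here could not show this, as none of them formed a pair differing only at this spot; here the compound with trifluoromethyl has the lower number and the compound with bare hydrogen the higher one. Nothing measured here gives a reason for this step.

A single pair cannot tell whether trifluoromethyl is special or whether a chlorine atom, a methyl group, a nitrile or an amine at the same place would also give a lower number than hydrogen, and compound 1 cannot settle this for its nitro group, as it also differs from compound 2 in the attachment point on the amine-bearing ring. Going by these compounds, it also remains open whether the same change made on compound 3 would give a step of similar size.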